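The source may hold more compounds than are shown below. What is called first, only, known or untested is meant among the compounds shown, and "the series" means these compounds.

Measured so far in a functional assay on P388 cells (Mus musculus) for cytotoxicity, read by MTT assay, with a stated time of 72 h; on this read-out lower numbers stand for stronger inhibition and higher numbers for weaker inhibition:
compound 1, `CCOc1cccc(/C=N/c2c(C)n(C)n(-c3ccccc3)c2=O)c1`, gives 295000000 nM;
compound 2, `Cc1c(/N=C/c2ccccc2Cl)c(=O)n(-c2ccccc2)n1C`, gives 324000000 nM;
compound 3, `Cc1c(/N=C/c2cccc([N+](=O)[O-])c2)c(=O)n(-c2ccccc2)n1C`, gives 490000000 nM.

Compound 3 gives the highest of the three numbers in this assay, but it stands within the scatter of both neighbours: compound 2 lies close below it, and compound 1 a little further below. No order among the three can be read from these values.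

Compound 4, `Cc1c(/N=C/c2ccccc2)c(=O)n(-c2ccccc2)n1C`, differs from compound 3 in one place: hydrogen in place of nitro on an aromatic carbon. Among the compounds with values here, only one measured step bears on this change, the one that also touches the same position of the aromatic ring: a 1.7-fold higher number from compound 1 to compound 3 (0.22 log units; within the scatter). That exchange of one substituent for another left the number where it was. Removing the nitro altogether is therefore expected to give no step beyond the scatter in this assay either, with the estimated step of a 1.2-fold lower number from compound 3 to compound 4 (0.09 log units; within the scatter). Compound 4 is accordingly expected to give about 400000000 nM, with a range from 150000000 nM to 1000000000 nM.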

Compound 4, half-maximal inhibitory concentration: 240000000 nM
For compound 4 the middle estimate is 1.7-fold (0.22 log units) above the measured one; measured number inside the range.
By their numbers in this assay, from the lowest: compounds 4, 1, 2 and 3 (each within the scatter of the next, the first and the last beyond it).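

In this assay, within the data shown here, the exchange of nitro for hydrogen is the first change on this aromatic carbon to reach beyond the scatter, a 2.0-fold lower number from compound 3 to compound 4 (0.31 log units; beyond the scatter), though only modestly. Hydrogen in place of chloro, a 1.4-fold lower number from compound 2 to compound 4 (0.13 log units; within the scatter), and hydrogen in place of ethoxy, a 1.2-fold lower number from compound 1 to compound 4 (0.09 log units; within the scatter), both stay within the scatter, so among these compounds only the pair with nitro and hydrogen can be told apart, and nitro does not separate from ethoxy, a 1.7-fold higher number from compound 1 to compound 3 (0.22 log units; within the scatter). Nothing available explains this one step.

The compounds shown leave open whether an amine or a carboxylic acid on this aromatic carbon would give a larger step from compound 4, in either direction. They also leave open whether nitro elsewhere on this ring would give the same step.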